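The compounds below may be only part of what the source reports. "The series", "measured", "known", "first", "only" and "open" are said of these compounds alone.

Measured so far in an assay on HEK293 cells for positive allosteric modulation of metabotropic glutamate receptor 2 (Rattus norvegicus), read by thallium flux, with a stated time of 2.5 min; a lower number here means that less compound is needed, a higher number that more compound is needed for the effect:

compound 1, `CCCC(=O)c1ccc(OCCCCOc2cccc(C(=O)O)c2C)c(C)c1O`, gives 52 nM
compound 2, `Cc1c(OCCCCOc2ccc(C(=O)C(C)C)c(O)c2C)cccc1C(=O)O`, gives 149 nM
compound 3, `CCCC(=O)c1ccc(OCCCCOc2ccc(C(=O)O)cc2C)c(C)c1O`, gives 104 nM

Compound 1 and compound 2 differ in one place: isopropyl in place of propyl on a carbonyl carbon. This change gave a 2.9-fold higher number from compound 1 to compound 2 (0.46 log units; beyond the scatter), a step that lies beyond the scatter. Compound 3 carries a different core from compound 1; the difference between the two cores is not broken down here. The values of compound 3 and compound 2 lie within the scatter of each other, as do those of compound 3 and compound 1, so no order among these three is claimed.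

Compound 4, `Cc1cc(C(=O)O)ccc1OCCCCOc1ccc(C(=O)C(C)C)c(O)c1C`, is not yet measured. It differs from compound 3 by isopropyl in place of propyl on a carbonyl carbon, and the surroundings of the change are the same as in the pair compound 1 to compound 2, so this is the same change made on the core of compound 3. For the measured compounds named here, whether it carries over is untested, with only one earlier instance to go on. Because the earlier instance gave a 2.9-fold higher number from compound 1 to compound 2 (0.46 log units; beyond the scatter), a step of similar size is expected here, a 2.7-fold higher number from compound 3 to compound 4 (0.43 log units; beyond the scatter). For compound 4 the expected value in this assay is 280 nM, estimated to fall between 120 nM and 650 nM.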

Compound 4, half-maximal effective concentration: 234 nM
The estimate for compound 4 lay 1.2-fold (0.08 log units) above the measured number, and the stated range covers the measured number.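

Isopropyl in place of propyl on a carbonyl carbon, carried onto a second core, gave in this assay a 2.3-fold higher number from compound 3 to compound 4 (0.35 log units; beyond the scatter), so the direction of the earlier step is repeated and this step too lies beyond the scatter. The sizes of the two steps do not separate: the same change on two cores in this assay, a 2.9-fold higher number (0.46 log units; beyond the scatter) from compound 1 to compound 2 and a 2.3-fold higher number (0.35 log units; beyond the scatter) from compound 3 to compound 4, 1.3-fold (0.11 log units) apart, within the scatter of two such steps. This shows that the change carries over between these two closely related cores in this assay, but two cores are a narrow base for a general rule, and the numbers give no explanation for the step.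

The compounds shown leave open whether a longer chain such as butyl, or a cyclopropyl group, on the same carbonyl carbon would continue the trend set by propyl and isopropyl. They also leave open whether the step would hold on a core in which an amide or a tetrazole takes the place of the carboxylic acid.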